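A few compounds are considered here, and "the series" means these few. Any claim that something is new, unique, unknown or untested is made for them only; others in the source may bear on it.

Measured so far in a functional assay on HL-60 cells (Homo sapiens) for antiproliferative activity, read by MTT assay; a higher number here means a weaker inhibitor, a lower number a stronger inhibitor:

compound 1, `C=CC[C@@H]1O[C@H](COCc2ccccc2)[C@@H](OCc2ccccc2)[C@H](OCc2ccccc2)[C@@H]1O`: "not active" (no number reported)
compound 2, `CCC[C@@H]1O[C@H](COC)[C@@H](OC)[C@H](OC)[C@H]1O`: "not active" (no number reported)
compound 3, `C=CC[C@@H]1O[C@H](COCc2ccccc2)[C@@H](OCc2ccccc2)[C@H](OCc2ccccc2)[C@H]1O`: 15100 nM

Within the data shown here, compound 1 stands without a single number in this assay, and compound 2 likewise comes without one; compound 3 is the only member with a reported figure, and that figure sits in the weak range. The pair of compound 1 and compound 3 is worth noting for (the fact that compounds 1 and 3 differ only in the configuration as drawn), yet one of them is reported without a number and the other with a weak one, so nothing firm can be drawn from that pair about what the shared core tolerates.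

The next member is compound 4, `CC(C)C[C@@H]1O[C@H](COCc2ccccc2)[C@@H](OCc2ccccc2)[C@H](OCc2ccccc2)[C@@H]1O`. Relative to compound 1 the change is isopropyl in place of vinyl on a saturated chain carbon bound to a saturated ring carbon. Among the measured compounds shown here, no measured step runs in parallel to this change, so there is no number to lean on. Given that compound 1 is reported as not active, the expectation for this step in this assay is no movement beyond the scatter, with compound 4 most probably also landing in the weak or unreported range. If a number does come out, compound 4 is estimated at 30000 nM, expected between 8000 nM and 100000 nM.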

Compound 4, half-maximal inhibitory concentration: "not active" (no number reported)
Compound 4 has no reported number here, and the estimate cannot be compared.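

Compound 1 gives "not active" (no number reported) and compound 4 gives "not active" (no number reported) in this assay, so no step can be read from allyl to isobutyl, and nothing at hand bears on this result. Still open, as far as these compounds go, is whether isobutyl in place of allyl would shift activity in the configuration of compound 3, which gives 15100 nM.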